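Swapping 4-hydroxy-2-methylphenyl for 4-ethylphenyl

The source may hold more compounds than are shown below. What is called first, only, known or untested is meant among the compounds shown, and "the series" means these compounds.

Among the measured compounds shown here, in a functional assay on MCF7 cells (Homo sapiens) for inhibition, read by sulforhodamine B assay, with a stated time of 48 h (on this read-out lower numbers stand for stronger inhibition of growth and higher numbers for weaker inhibition of growth), compound 2 `Cc1cc(O)ccc1C1=NN(c2ccc(S(C)(=O)=O)cc2)C(=O)CC1` gives 20700 nM, the higher of the two numbers measured so far. Compound 1 `Cc1ccc(C2=NN(c3ccc(S(C)(=O)=O)cc3)C(=O)CC2)cc1` gives 1380 nM in this assay. For the measured compounds named here, only one measured step bears on what follows: a 15-fold higher number from compound 1 to compound 2 (1.18 log units; beyond the scatter), a large change that came with 4-hydroxy-2-methylphenyl in place of 4-methylphenyl. Compound 3 `CCc1ccc(C2=NN(c3ccc(S(C)(=O)=O)cc3)C(=O)CC2)cc1` is reached from compound 2 by a single change: 4-ethylphenyl in place of 4-hydroxy-2-methylphenyl on a carbon with a double bond to nitrogen. Like compound 1, compound 3 has no hydroxy group, so a large move back towards lower numbers in this assay is expected, roughly matching the measured step in size. Going by the values given here, no compound bearing 4-ethylphenyl has yet been measured, so the range stays wide. The expected change is a 14-fold lower number from compound 2 to compound 3 (1.14 log units; beyond the scatter). For compound 3, the estimated value is 1500 nM, with an expected range of 500 nM to 4500 nM.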

Compound 3, concentration for 50% growth inhibition: 3130 nM
Compound 3: middle estimate off by 2.1-fold (0.32 log units), on the low side; the measured number falls inside the stated range.
By their numbers in this assay, from the lowest: compound 1; then compound 3; then compound 2.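

In this assay, among the compounds shown here, replacing the 4-hydroxy-2-methylphenyl group with 4-ethylphenyl gives a 6.6-fold lower number from compound 2 to compound 3 (0.82 log units; beyond the scatter), so a group without the hydroxy again gives a lower number, although this step is smaller than the one that separates compound 1 from compound 2. The position also responds to a much smaller change, as methyl in place of hydrogen on the saturated chain carbon gives a 2.3-fold higher number from compound 1 to compound 3 (0.36 log units; beyond the scatter), a modest step that still lies beyond the scatter. Nothing measured here gives a cause for either step.

The compounds shown leave open whether a longer chain such as propyl would raise the number further. They also leave open how the hydroxy and the methyl of compound 2 each contribute, and what an amine or a methoxy group would do on this ring.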